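The source may hold more compounds than are shown below. What is called first, only, known or untested is meant among the compounds shown, and "the series" means these compounds.

Measured compounds:
compound 1 `Cc1cc(S(=O)(=O)NC(=O)c2ccc(N3CCN(Cc4ccccc4-c4ccc(Cl)cc4)CC3)cc2)ccc1N[C@H](CCN(C)C)CSc1ccccc1` < 1 nM
compound 2 `CN(C)CC[C@H](CSc1ccccc1)Nc1ccc(S(=O)(=O)NC(=O)c2ccc(N3CCN(CC4=C(c5ccc(Cl)cc5)CCCCC4)CC3)cc2)cc1[N+](=O)[O-]` < 1 nM
compound 3 `CN(C)CC[C@H](CSc1ccccc1)Nc1ccc(S(=O)(=O)NC(=O)c2ccc(N3CCN(CC4=C(c5ccc(Cl)cc5)CCOC4)CC3)cc2)cc1[N+](=O)[O-]` 2.4 nM

All three were tested in an assay on isolated protein for displacement of a labelled ligand from Apoptosis regulator Bcl-2 (Homo sapiens), read by fluorescence polarization; on this read-out lower numbers stand for stronger inhibition and higher numbers for weaker inhibition. In this assay compound 1 gives < 1 nM, which is a limit of the assay and not a number. Compound 2 likewise gives < 1 nM, again a limit. Compound 3 gives 2.4 nM, a measured number. Compound 1 therefore stands at the limit of < 1 nM in this assay, at which 2 of the 3 values shown sit, and the numbers shown do not tell how far past that limit it reaches. Within the data shown here, no two of the measured compounds differ in only one place, so no single step between them can be read off.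

Compound 4 `CN(C)CC[C@H](CSc1ccccc1)Nc1ccc(S(=O)(=O)NC(=O)c2ccc(N3CCN(Cc4ccccc4-c4ccc(Cl)cc4)CC3)cc2)cc1S(=O)(=O)C(F)(F)F` has not yet been measured in this assay. It arises from compound 1 by (trifluoromethyl)sulfonyl in place of methyl on an aromatic carbon; the rest of the shared core is kept. Because compound 1 already sits at the limit of < 1 nM in this assay, at which 2 of the 3 values shown sit, any gain from this change would be hidden by the limit, and a loss would have to be large to bring compound 4 into the range where a number is reported. The account therefore expects the step from compound 1 to compound 4 to be a step that the limit leaves unreadable from compound 1 to compound 4, that is, nothing beyond the scatter. For compound 4 the estimate is 0.8 nM, with a range from 0.2 nM to 3 nM, and a real chance that this assay again reports only the limit.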

Compound 4, inhibition constant: < 1 nM
Compound 4: no number, only a limit; the forecaster's own chance of this, stated with the estimate: 60%; the middle value lies beyond the limit too.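

No step can be read from compound 1 to compound 4, because both compounds give only a limit of the assay and not a number: the limit of < 1 nM in this assay, at which 3 of the 4 values shown sit.

The compounds shown leave open how far compound 1 and compound 4 reach past that limit in this assay, and so whether (trifluoromethyl)sulfonyl in place of methyl changes the read-out at all.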